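Nitric oxide inhibition in macrophage cells: from compound 3 to 4

The source may hold more compounds than are shown below. What is called first, only, known or untested is meant among the compounds shown, and "the series" means these compounds.

Measured compounds:
compound 1, `Cc1noc(CC2OC(=O)c3ccccc32)n1`: > 10000 nM
compound 2, `O=C1OC(Cc2nc(-c3ccc(Oc4ccccc4)cc3)no2)c2ccccc21`: > 10000 nM
compound 3, `COCCCOc1ccc(C(O)C2OC(=O)c3c(OC)cc(OC)cc32)cc1`: 1260 nM

Of the compounds shown here, three have been tested in a functional assay on RAW264.7 cells (Mus musculus) for inhibition, read by Griess assay, with stated times of 1 h and 24 h; on this read-out higher numbers stand for weaker inhibition and lower numbers for stronger inhibition. Compound 1 gives > 10000 nM, which is a limit of the assay rather than a number. Compound 2 likewise gives > 10000 nM, again a limit. Within the data shown here, compound 3 is the only one with a measured number, 1260 nM in this assay, and it therefore stands alone against (the limit of > 10000 nM in this assay, at which 2 of the 3 values shown sit).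

Compound 4, `COc1cc(OC)c2c(c1)C(C(O)c1ccc(OCc3ccc(OC(F)(F)F)cc3)cc1)OC2=O`, has not yet been measured. It differs from compound 3 in one place: 4-(trifluoromethoxy)phenyl in place of 2-methoxyethyl on a saturated chain carbon bound to an oxygen on an aromatic ring. Among the measured compounds shown here, since no step between two measured compounds is available, there is nothing here to calibrate how much such a change moves the read-out. A step of modest size toward stronger inhibition is expected, though one within the usual scatter would not be surprising. For compound 4 the estimate in this assay is 700 nM, with a range from 150 nM to 3000 nM, which corresponds to an expected step of a 1.8-fold lower number from compound 3 to compound 4 (0.26 log units; within the scatter).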

Compound 4, half-maximal inhibitory concentration: 8140 nM
The estimate for compound 4 lay 12-fold (1.07 log units) below the measured number; measured number outside the range, above it.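

Among these compounds, replacing 2-methoxyethyl with 4-(trifluoromethoxy)phenyl, on a saturated chain carbon bound to an oxygen on an aromatic ring, gives the first step in this set that can be read in this assay, and it is a 6.5-fold higher number from compound 3 to compound 4 (0.81 log units; beyond the scatter). This shows that inhibition is not indifferent to the group at this place, and that in this one pair the group with the aromatic ring goes with weaker inhibition. Compound 4 still gives a measured number, whereas the top of the readable scale is a limit of the assay and not a number: the limit of > 10000 nM in this assay, at which 2 of the 4 values shown sit.

A single step cannot separate the part played by the aromatic ring from that of the trifluoromethoxy group it carries. On these data alone, how a plain phenyl, an amine or a carboxylic acid would read at this place remains open.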